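The source may report more compounds than this note shows. Statements on the series, on what has been measured and on what is new or still open speak of the compounds shown alone.

Of the compounds shown here, three have been measured for tolerance by mouse hepatocytes.

Compound 1 `Cc1ccc(-c2nn(-c3ccccc3)cc2-c2nc3ccccc3n2S(=O)(=O)c2ccc(Br)cc2)cc1`: in an ADME assay on cells (Hepatocyte, Mus musculus) for cytotoxicity, read by MTT assay, with a stated time of 24 h (a higher number here means that more compound is tolerated, a lower number that less compound is tolerated), compound 1 reaches only the limit > 300000 nM.
Compound 2 `Cc1ccc(-c2nn(-c3ccccc3)cc2-c2nc3ccccc3n2S(=O)(=O)c2ccc(C(F)(F)F)cc2)cc1`: in this assay compound 2 gives 89300 nM.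
Compound 3 `O=S(=O)(c1ccc(Br)cc1)n1c(-c2cn(-c3ccccc3)nc2-c2ccc(F)cc2)nc2ccccc21`: in this assay compound 3 also stops at the limit > 300000 nM.

Compound 3 differs from compound 1 by fluoro in place of methyl on an aromatic carbon, and the step that the two limits leave unreadable from compound 1 to compound 3 because both values sit at the limit of > 300000 nM in this assay, at which 2 of the 3 values shown sit. Compound 2 differs from compound 1 by trifluoromethyl in place of bromo on an aromatic carbon, and the step is an at least 3.3-fold lower number from compound 1 to compound 2 (0.52 log units; beyond the scatter).

Compound 4 `O=S(=O)(c1ccc(C(F)(F)F)cc1)n1c(-c2cn(-c3ccccc3)nc2-c2ccc(F)cc2)nc2ccccc21` is not yet measured; it differs from compound 3 by trifluoromethyl in place of bromo on an aromatic carbon, the same change that was made from compound 1 to compound 2. Compound 4 is expected to show a step of an at least 3.0-fold lower number from compound 3 to compound 4 (0.47 log units; beyond the scatter) in this assay. Compound 4 is therefore estimated at 100000 nM, between 30000 nM and 300000 nM, because compound 2 gives 89300 nM.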

Compound 4, half-maximal cytotoxic concentration: 55300 nM
Estimate against measurement, compound 4: 1.8-fold (0.26 log units) above; the range from low to high includes it.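

In this assay, trifluoromethyl in place of bromo gives an at least 5.4-fold lower number from compound 3 to compound 4 (0.73 log units; beyond the scatter), so the number falls on the core of compound 3 as it does on the core of compound 1, and the direction carries across these two cores: the same change on two cores in this assay, an at least 3.3-fold lower number (0.52 log units; beyond the scatter) from compound 1 to compound 2 and an at least 5.4-fold lower number (0.73 log units; beyond the scatter) from compound 3 to compound 4; the limit leaves it open whether they differ. What this does not show is the full size of either step, as compound 1 and compound 3 both stop at a limit rather than a number: the limit of > 300000 nM in this assay, at which 2 of the 4 values shown sit. With trifluoromethyl in place on both cores, fluoro in place of methyl gives a 1.6-fold lower number from compound 2 to compound 4 (0.21 log units; within the scatter), so the two cores do not separate there.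

The compounds shown leave open how a nitrile or a carboxylic acid in the same place would read in this assay. They also leave open whether the change carries to any core beyond these two.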